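Fluoro, Bromo and Phenylethyl on the Piperazine Nitrogen

The source may hold more compounds than are shown below. What is called first, only, known or untested is meant among the compounds shown, and "the series" means these compounds.

Of the compounds shown here, two on a shared core have been measured in an assay on CHO cells for displacement of a labelled ligand from adenosine receptor A3 (Homo sapiens), read by scintillation counting, with a stated time of 45 min, tested at 1 uM, in the presence of a further agent that is not named here; a higher number here means more inhibition at the concentration tested (going by the name of the read-out), a lower number less inhibition. Compound 1 `CCCn1c(=O)[nH]c2nc(-c3ccc(S(=O)(=O)N4CCN(c5cccc(Br)c5)CC4)cc3)[nH]c2c1=O` gives 27%, and compound 2 `CCCn1c(=O)[nH]c2nc(-c3ccc(S(=O)(=O)N4CCN(c5cccc(F)c5)CC4)cc3)[nH]c2c1=O` gives 44%. Among the measured compounds shown here, the single step between them, fluoro in place of bromo on an aromatic carbon, is a number 17 percentage points higher from compound 1 to compound 2 (beyond the scatter). Compound 2 thus holds the highest of the two numbers, with compound 1 as its nearest neighbour at a number lower than it beyond the scatter.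

Compound 3 `CCCn1c(=O)[nH]c2nc(-c3ccc(S(=O)(=O)N4CCN(C(C)c5ccccc5)CC4)cc3)[nH]c2c1=O` is the next compound to be measured. It differs from compound 2 in one place: 1-phenylethyl in place of 3-fluorophenyl on an amine nitrogen in a ring. For the measured compounds named here, the only measured step, which swapped one halogen for another on the aryl ring, bears on this change only loosely, because a number 17 percentage points higher from compound 1 to compound 2 (beyond the scatter) speaks to the aryl substituent and not to the exchange of an aryl group for a 1-phenylethyl group. Going by the values given here, no measured pair shows what such an exchange does here. Compound 3 is therefore expected to give 35% in this assay, within a range of 10% to 60%, which means an expected step of a number 9 percentage points lower from compound 2 to compound 3 (within the scatter) and no direction that can be stated with confidence.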

Compound 3, a percentage reported as inhibition, at one concentration (the size of the read-out at that concentration, not a potency): 0%
Estimate against measurement, compound 3: 35 percentage points above, and the stated range ends above it.
By their numbers in this assay, from the lowest: compound 3; then compound 1; then compound 2.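

This position on an amine nitrogen in a ring proves sensitive to what is attached there, not only to the halogen on the aryl ring: in this assay, 1-phenylethyl in place of 3-fluorophenyl gives a number 44 percentage points lower from compound 2 to compound 3 (beyond the scatter), and 1-phenylethyl in place of 3-bromophenyl gives a number 27 percentage points lower from compound 1 to compound 3 (beyond the scatter). The loss appears with both halogenated partners, and compound 3 gives 0%, even though the exchange keeps one six-membered aromatic ring of carbon only, adds no hydrogen-bond donors or acceptors and brings no net charge. No measurement available here explains the fall.

The exchange alters several things at once, since the halogen goes, the aromatic ring no longer sits directly on the nitrogen and a branching methyl appears, so the three compounds cannot show which of these matters. An unsubstituted phenyl on the same nitrogen would isolate the halogen's part, while an unbranched benzyl group would separate the inserted carbon from the methyl branch, and the compounds shown hold neither comparison.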